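Pyrimidine to Thiazole on a Thioether Linker

This account rests on a few compounds, and the source may have more. Where it says the series, first, only, none or still open, it means among the compounds named here.

Compound 1 `O=c1cc(CNc2ccccc2)c2ccc(O)cc2o1`: 4000 nM
Compound 2 `O=c1cc(CSc2ncccn2)c2ccc(O)cc2o1`: 1000 nM

Both compounds were tested in an assay on HeLa cells for inhibition of 17-beta-hydroxysteroid dehydrogenase type 3 (Homo sapiens); on this read-out lower numbers stand for stronger inhibition and higher numbers for weaker inhibition. Compound 2 gives the lower of the two numbers, and compound 1 sits above it by a gap that is beyond the usual scatter. Compound 3 `O=c1cc(CSc2nccs2)c2ccc(O)cc2o1` has not been measured. Its difference from compound 2 is 1,3-thiazol-2-yl in place of pyrimidin-2-yl on a sulfur. Within the data shown here, no measured pair shows this kind of exchange, so the size of the step is unknown; with two aromatic rings of similar make-up swapped on the same sulfur, no step beyond the scatter is expected in either direction. Compound 3 is therefore expected to give about 1000 nM, with a range from 300 nM to 3000 nM, an estimated step of no change at the digits printed from compound 2 to compound 3 (within the scatter).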

Compound 3, half-maximal inhibitory concentration: 10 nM
Beside the measured number, compound 3's estimate is 100-fold (2.00 log units) above it; measured number below the stated range.
By their numbers in this assay, from the lowest: compound 3; then compound 2; then compound 1.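

In this assay the ring on the sulfur matters far more than its make-up suggests: 1,3-thiazol-2-yl in place of pyrimidin-2-yl gives a 100-fold lower number from compound 2 to compound 3 (2.00 log units; beyond the scatter) even though both rings have the same counts of hydrogen-bond donors and acceptors and no net charge. This position is therefore highly sensitive to swapping one aromatic ring for another, which compound 1 and compound 2, differing in more than one place, could not show. Nothing available explains the size of this step. As far as these compounds go, whether it follows from the ring sulfur, the five-membered ring or something else remains open. So does how a 1,3-oxazol-2-yl or pyridin-2-yl group, or an amine on the thiazole ring, would behave here.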